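Saturating the Chain End of Compound 1

The source may hold more compounds than are shown below. What is called first, only, known or untested is meant among the compounds shown, and "the series" means these compounds.

Among the measured compounds shown here, the three compounds measured so far share a core that carries a hydroxyl at one end of the chain and an unsaturated tail at the other. Compound 1 `C=CCCCCCC#CC#CCO` is the parent; in a functional assay on SK-MEL-2 cells (Homo sapiens) for cytotoxicity (on this read-out higher numbers stand for an effect only at larger amounts of compound and lower numbers for an effect already at smaller amounts), compound 1 gives 9.56 ug/mL. Compound 2 `C=CCCCCCC#CC#CC(O)CC(C)=O` gives 3.74 ug/mL, and compound 3 `C=CCCCCCC#CC#CCOCCO` gives 25.1 ug/mL. Compound 1 thus stands second highest of the three numbers: the step of a 2.6-fold lower number from compound 1 to compound 2 (0.41 log units; beyond the scatter) is its nearest neighbour, while the step of a 2.6-fold higher number from compound 1 to compound 3 (0.42 log units; beyond the scatter) is the furthest.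

Compound 4 `CCCCCCCC#CC#CCO` has not yet been measured. Compared with compound 1 the change is ethyl in place of vinyl on a saturated chain carbon, five bonds along the chain from a triple-bonded carbon. For the measured compounds named here, both measured steps alter the end of the chain that bears the oxygen, and neither touches the end where the vinyl sits, so no measured step bears directly on this change. Going by the values given here, the only anchor is the value of compound 1 itself, and the change leaves donors and acceptors unchanged. The expected outcome is therefore a 1.0-fold higher number from compound 1 to compound 4 (0.02 log units; within the scatter), that is, nothing beyond the usual scatter. For compound 4 the estimate is 10 ug/mL, with a range from 4 ug/mL to 25 ug/mL.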

Compound 4, concentration for half-maximal effect: 4.45 ug/mL
Beside the measured number, compound 4's estimate is 2.2-fold (0.35 log units) above it, within the range that was stated.
By their numbers in this assay, from the lowest: compounds 2 and 4 (each within the scatter of the next); then compound 1; then compound 3.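

Among the compounds shown here, the end of the chain that the earlier steps left untouched proves to matter in this assay: ethyl in place of vinyl, on a saturated chain carbon, five bonds along the chain from a triple-bonded carbon, gives a 2.1-fold lower number from compound 1 to compound 4 (0.33 log units; beyond the scatter), a step beyond the scatter. The change removes the double bond of the vinyl group while the heavy atoms, donors and acceptors, as counted for the two groups, stay matched, and the step runs in the same direction and is of the same modest size as a 2.6-fold lower number from compound 1 to compound 2 (0.41 log units; beyond the scatter), which was made at the oxygen-bearing end. No measurement at hand gives a reason for this shift.

Whether the lower number goes with the loss of the double bond as such cannot be told from this single change, and a longer chain, a terminal triple bond or a phenyl group at this end would be needed to show how far the effect extends. Also open is whether this step adds to those at the other end, since the 2-oxopropyl and 2-hydroxyethyl groups appear only with the vinyl end in the compounds shown.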